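The source may hold more compounds than are shown below. What is called first, only, known or untested is meant among the compounds shown, and "the series" means these compounds.

Working notes on the series. In an ADME assay for lipophilicity (a lower number here means a more polar compound, a higher number a more lipophilic compound), compound 1 (`O=c1ccocc1O`) gives -0.92 and compound 2 (`COCc1cc(=O)c(O)co1`) gives -0.62 on the same scale. Among the compounds with values here, these two values lie within the scatter of each other, so compound 1 holds no separate place on the numbers so far. Compound 3 (`CCOCc1cc(=O)c(O)co1`) has not yet been measured. Its difference from compound 1 is ethoxymethyl in place of hydrogen on an aromatic carbon in the form of ethoxymethyl in place of hydrogen on an aromatic carbon, next to the ring oxygen. Within the data shown here, one measured step bears on this change, the replacement of the same hydrogen by methoxymethyl in compound 2, which amounts to a number 0.30 log units higher from compound 1 to compound 2 (within the scatter) and so gives only weak guidance. Ethoxymethyl is the larger group of the two, so a step in the same direction and somewhat larger than that one is expected in this assay with clear uncertainty. The estimated change is a number 0.67 log units higher from compound 1 to compound 3 (beyond the scatter) on this single precedent. For compound 3 the estimated value is -0.25 with an expected range from -0.6 to 0.1 at this stage.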

Compound 3, distribution coefficient: -0.38
For compound 3 the middle estimate is 0.13 log units above the measured one; the measured number falls inside the stated range.
By their numbers in this assay, from the lowest: compounds 1, 2 and 3 (each within the scatter of the next, the first and the last beyond it).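

Within the data shown here, with ethoxymethyl in place of hydrogen on the aromatic carbon next to the ring oxygen, this assay gives a number 0.54 log units higher from compound 1 to compound 3 (beyond the scatter) as the first step at this position that lies beyond the scatter, which the methoxymethyl compound 2 did not provide. The further change in the chain, methyl in place of hydrogen on a saturated chain carbon bound to an oxygen, amounts to a number 0.24 log units higher from compound 2 to compound 3 (within the scatter) and so cannot be told apart from repeat measurement on its own. The series therefore separates only its two end members, compound 1 and compound 3, while compound 2 lies within the scatter of each, and a single step beyond the scatter at one position is too little to establish a trend with chain length.

Open questions are whether a longer chain such as butoxymethyl would extend this difference, and whether an amine or a carboxylic acid on the same aromatic carbon would give a step in the opposite direction. The data shown include no measurement that explains the size of any of these steps.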